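Trimming the Alkyl Group on a Shared Fused Core

The compounds below may be only part of what the source reports. "The series", "measured", "known", "first", "only" and "open" are said of these compounds alone.

Measured compounds in a functional assay on HL-60 cells (Homo sapiens) for cytotoxicity, read by MTT assay, with a stated time of 72 h; on this read-out lower numbers stand for stronger inhibition and higher numbers for weaker inhibition:
- Compound 1, `CC(C)(C)c1nnc2nnc(N3CCCC3)nn12`, gives > 100000 nM, which is a limit of the assay and not a number.
- Compound 2, `CC(C)c1nnc2nnc(N3CCCC3)nn12`, gives 71200 nM.

Going by the values given here, compound 2 therefore stands as the only actual number in this assay; the one other value shown is a limit rather than a measurement. The next compound to be measured is compound 3, `CCc1nnc2nnc(N3CCCC3)nn12`. It differs from compound 2 by hydrogen in place of methyl on a saturated chain carbon bound to an aromatic carbon and a saturated chain carbon.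

Among the compounds with values here, only one measured step bears on this change. Going an at least 1.4-fold lower number from compound 1 to compound 2 (0.14 log units; that floor lies within the scatter) also removed a methyl from the saturated carbon attached to the core, and its size is bounded only by the limit of > 100000 nM in this assay, at which 1 of the 2 values shown sits, so the change is at best modest and lies within the usual scatter. Repeating the same kind of trimming one carbon further gives no basis for a large step; if anything, a slightly lower number is expected, but nothing beyond the scatter can be claimed.

Compound 3 is therefore estimated to give 50000 nM, with a range from 20000 nM to 120000 nM. The step this estimate means is expected to be a 1.4-fold lower number from compound 2 to compound 3 (0.15 log units; within the scatter).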

Compound 3, half-maximal inhibitory concentration: 47000 nM
Beside the measured number, compound 3's estimate is 1.1-fold (0.03 log units) above it; low and high end bracket the measured number.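

In this assay, trimming isopropyl to ethyl gives a 1.5-fold lower number from compound 2 to compound 3 (0.18 log units; within the scatter), so this single change leaves the two values indistinguishable, and the position now has two actual numbers instead of one. Taken as a whole, the change from tert-butyl to ethyl gives an at least 2.1-fold lower number from compound 1 to compound 3 (0.32 log units; beyond the scatter), the first step at this position printed as beyond the scatter, which suggests that the full trimming can matter even though the last single step cannot be resolved. As far as these compounds go, the value of compound 1 is a limit and not a number, so only the floor of that larger step is known, and its true size stays unknown: the limit of > 100000 nM in this assay, at which 1 of the 3 values shown sits.

From the compounds shown here alone, the three compounds cover only branched and short alkyl groups on this carbon of the shared core, so it remains open whether a longer chain, a cyclopropyl ring or an amine in the same place would lower the number further or raise it again. Going by these compounds, all three also keep the rest of the structure the same, so it is unknown whether this trend would hold with a different group elsewhere on the core.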